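A Methoxy Group Removed From the Core of Compound 1

This account rests on a few compounds, and the source may have more. Where it says the series, first, only, none or still open, it means among the compounds named here.

Compound 1 (`COc1ccc2sc(/C=C\c3cc(OC)c(OC)c(OC)c3)cc2c1`): "not determined" (no result reported) 
Compound 2 (`COc1ccsc1/C=C\c1cc(OC)c(OC)c(OC)c1`): > 1000 nM 

The antiproliferative data come from a functional assay on MIA PaCa-2 cells (Homo sapiens) for antiproliferative activity, read by MTT assay, with a stated time of 72 h; on this read-out lower numbers stand for stronger inhibition and higher numbers for weaker inhibition. Compound 1 has no single number there, and its entry reads ("not determined" (no result reported)). Compound 2 gives only a limit in this assay (> 1000 nM). The sole reference point for judging compound 1 is therefore (the limit of > 1000 nM in this assay, at which 1 of the 2 values shown sits), which places it nowhere on the scale.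

The account now turns to compound 3 (`COc1cc(/C=C\c2cc3ccccc3s2)cc(OC)c1OC`). It has hydrogen in place of methoxy on an aromatic carbon. For the measured compounds named here, no measured pair shows what this change does, so no step beyond the scatter is expected in this assay. Compound 3 is estimated at 1500 nM (expected range 200 nM to 10000 nM).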

Compound 3, half-maximal inhibitory concentration: 7.8 nM
The estimate for compound 3 lay 190-fold (2.28 log units) above the measured number; measured number outside the range, below it.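

In this assay compound 3 gives 7.8 nM, but compound 1 has no single number to set against it, so no step can be read between compound 1 and compound 3. As far as these compounds go, what the methoxy group on the core of compound 1 contributes remains open.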